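A few compounds are considered here, and "the series" means these few. Any claim that something is new, unique, unknown or untested is made for them only; others in the source may bear on it.

The series shares one core, seen in compound 1 `Cc1ccc(-c2ccc(NC3=CC(=O)c4ncncc4C3=O)cc2F)cc1`, compound 2 `O=C1C(Nc2ccc(Oc3ccccc3)cc2)=CC(=O)c2ncncc21` and compound 3 `O=C1C(NCc2ccc(F)cc2)=CC(=O)c2ncncc21`, and differs only in the group attached to its amino nitrogen. In a functional assay on BXPC-3 cells (Homo sapiens) for cytotoxicity, read by MTT assay, with a stated time of 72 h (a lower number here means a stronger inhibitor, a higher number a weaker inhibitor), compound 1 gives 5000 nM, compound 2 gives 3600 nM and compound 3 gives 1400 nM. Compound 2 thus holds the second highest of the three numbers: its number and that of compound 1 lie within the scatter of each other, so nothing separates those two, while compound 3 sits beyond the scatter with a clearly lower number.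

Compound 4 `CCOC(=O)c1ccc(NC2=CC(=O)c3ncncc3C2=O)cc1` has not yet been measured in this assay. It differs from compound 2 in one place: ethoxycarbonyl in place of phenoxy on an aromatic carbon. Within the data shown here, no measured pair in this set shows what this exchange does, so the size of the step has to be judged from the neighbours. Because compound 2 gives 3600 nM and compound 1, whose aromatic ring of carbon only also carries a large group, gives 5000 nM, a sizeable substituent on that ring has so far not moved the number beyond the scatter. The expected step is therefore a 1.1-fold higher number from compound 2 to compound 4 (0.05 log units; within the scatter), no larger than the scatter and in no firm direction. Compound 4 is estimated at 4000 nM, with a likely range from 1500 nM to 12000 nM.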

Compound 4, half-maximal inhibitory concentration: 5900 nM
Compound 4: the middle estimate sits 1.5-fold (0.17 log units) below what was measured; low and high end bracket the measured number.
By their numbers in this assay, from the lowest: compound 3; then compounds 2, 1 and 4 (each within the scatter of the next).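

In this assay, among these compounds, putting ethoxycarbonyl in place of phenoxy gives a 1.6-fold higher number from compound 2 to compound 4 (0.21 log units; within the scatter) and so provides the first direct reading at this position, where the earlier compounds offered no measured pair. On this aromatic carbon, a group with no ring and a double bond outside aromatic rings can replace one carrying a six-membered aromatic ring of carbon only, with the step staying within the scatter, so this one exchange shows no need for that second ring to keep the number in this range. The compounds shown offer no measurement that explains this outcome, and a single pair gives no firm direction for the change.

On these data alone, whether a carboxylic acid, a primary amide or an amine on the same aromatic carbon would leave the number in this range remains open, as does the outcome of a longer chain on the ester oxygen. It is also unresolved whether any group at this position can produce a step beyond the scatter, in either direction.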